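A few compounds are considered here, and "the series" means these few. Any claim that something is new, unique, unknown or untested is made for them only; others in the source may bear on it.

Of the compounds shown here, three have been measured in a functional assay on MV4-11 cells (Homo sapiens) for antiproliferative activity, read by resazurin assay, with a stated time of 72 h; a lower number here means a stronger inhibitor of growth, a higher number a weaker inhibitor of growth. Compound 1 `CC(=O)N1CCN(c2ccc(Nc3ncc(C#N)c(-c4n[nH]c5ccccc45)n3)cc2)CC1` gives 17 nM in this assay, the lowest of the three numbers. Compound 3 `CC(=O)N1CCCN(c2cccc(Nc3nccc(-c4c[nH]c5ncccc45)n3)c2)CC1` gives 20 nM in this assay, and compound 2 `CC(=O)N1CCN(c2ccc(Nc3nccc(-c4c[nH]c5ccccc45)n3)cc2)CC1` gives 33 nM in this assay. For the measured compounds named here, both of those numbers sit within the scatter of the number for compound 1, so no order among the three can be claimed, and no pair of measured compounds differs in just one place, so no single step is known. Compound 4 `CC(=O)N1CCN(c2ccc(Nc3ncc(C#N)c(-c4c(C)[nH]c5ccccc45)n3)cc2)CC1` has not been measured. It differs from compound 1 in one place: 2-methyl-1H-indol-3-yl in place of 1H-indazol-3-yl on an aromatic carbon. Going by the values given here, the only guidance is that compound 2, which carries an indole in place of the indazole but lacks the cyano group, gives 33 nM in this assay, within the scatter of compound 1. The step from compound 1 to compound 4 is therefore expected to be small, a 1.8-fold higher number from compound 1 to compound 4 (0.25 log units; within the scatter), toward a somewhat higher number if anything. Compound 4 is expected to give about 30 nM in this assay, with a range from 8 nM to 120 nM.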

Compound 4, concentration for 50% growth inhibition: 390 nM
Compound 4: the middle estimate sits 13-fold (1.11 log units) below what was measured; measured number above the stated range.
By their numbers in this assay, from the lowest: compounds 1, 3 and 2 (each within the scatter of the next); then compound 4.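

For the compounds shown here, putting 2-methyl-1H-indol-3-yl in place of 1H-indazol-3-yl gives a 23-fold higher number from compound 1 to compound 4 (1.36 log units; beyond the scatter) in this assay and is the first single change that can be read in this set. It shows that the aromatic carbon ortho to a cyano group and next to the ring nitrogen is sensitive to what it carries, since this one change moves the number far beyond the scatter. Nothing available bears on the reason for this loss. The change also alters two things at once, removing a ring nitrogen and adding a methyl, so the step cannot be divided between them. On these data alone, a plain 1H-indol-3-yl group on the core of compound 1 would separate the two, and whether a 3-methyl-1H-indazol-type group or an ethyl would fare differently remains open.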